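The source may hold more compounds than are shown below. What is called first, only, known or untested is meant among the compounds shown, and "the series" means these compounds.

Working notes on the series, step from compound 3 to compound 4.

Three compounds with the shared core are measured in an assay on microsomes from intestine for inhibition of acyl-CoA:cholesterol acyltransferase (Oryctolagus cuniculus); on this read-out higher numbers stand for weaker inhibition and lower numbers for stronger inhibition. Compound 1 `Cc1cc(C)c(NC(=O)N(Cc2ccc(N3CCN(C)CC3)cc2)C2CCCCCC2)c(C)c1` gives 57 nM. Compound 2 `Cc1cc(C)c(NC(=O)N(Cc2ccc(-c3ccsc3)cc2)C2CCCCCC2)c(C)c1` gives 19 nM. Compound 3 `Cc1cc(C)c(NC(=O)N(Cc2ccc(-c3cccnc3)cc2)C2CCCCCC2)c(C)c1` gives 130 nM, the highest number of the three; the step of a 2.3-fold higher number from compound 1 to compound 3 (0.36 log units; beyond the scatter) and the step of a 6.8-fold higher number from compound 2 to compound 3 (0.84 log units; beyond the scatter) both run upward to it, so compound 3 is the weakest inhibitor measured here. The remaining step, a 3.0-fold lower number from compound 1 to compound 2 (0.48 log units; beyond the scatter), shows the two-ring replacements at this position spreading the numbers over a modest span.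

Compound 4 `Cc1cc(C)c(NC(=O)N(Cc2ccc(-c3ccn(C)n3)cc2)C2CCCCCC2)c(C)c1` is not yet measured. It differs from compound 3 by 1-methyl-1H-pyrazol-3-yl in place of pyridin-3-yl on an aromatic carbon, the new group sitting para to a large group on the same six-membered ring of carbon only. The step that bears most directly is a 6.8-fold higher number from compound 2 to compound 3 (0.84 log units; beyond the scatter), where a five-membered ring replaced by a six-membered one raised the number; a 2.3-fold higher number from compound 1 to compound 3 (0.36 log units; beyond the scatter) points the same way. A return to a five-membered ring is therefore expected to move the number down, though less surely than with compound 2, since this ring carries two hetero atoms. The expected step is a 1.9-fold lower number from compound 3 to compound 4 (0.27 log units; within the scatter), and for compound 4 the estimate in this assay is 70 nM, within 25 nM to 250 nM.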

Compound 4, half-maximal inhibitory concentration: 44 nM
Estimate against measurement, compound 4: 1.6-fold (0.20 log units) above; the range from low to high includes it.
By their numbers in this assay, from the lowest: compound 2; then compounds 4 and 1 (each within the scatter of the next); then compound 3.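

In this assay, the step of a 3.0-fold lower number from compound 3 to compound 4 (0.47 log units; beyond the scatter) shows that the lower numbers at this position, para to a large group, are not confined to thiophen-3-yl: a second five-membered aromatic ring, here with 2 hetero atoms, also lies clear of pyridin-3-yl. Ring size alone does not settle the number, since the two five-membered rings themselves separate, with a 2.3-fold higher number from compound 2 to compound 4 (0.36 log units; beyond the scatter) as the step, and compound 2 remains the strongest inhibitor of the four. The step of a 1.3-fold lower number from compound 1 to compound 4 (0.11 log units; within the scatter) leaves 1-methyl-1H-pyrazol-3-yl and 4-methylpiperazin-1-yl indistinguishable on this read-out, although one is a five-membered aromatic ring and the other is not, so two quite different groups can give matching numbers here.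

Nothing available explains any of these steps. Still open, from the compounds shown here alone, is how a plain phenyl, a 1H-pyrazol-3-yl without the methyl or a carboxylic acid would read at this place, and so whether the methyl on the pyrazole or the hetero atoms of the ring account for the gap to thiophen-3-yl.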